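Chloro for methoxy: from compound 3 to compound 4

A few compounds are considered here, and "the series" means these few. Any claim that something is new, unique, unknown or untested is made for them only; others in the source may bear on it.

Measured so far:
compound 1 `C=CCn1c(=O)/c(=C\c2cc(F)ccc2C)[nH]c(=O)/c1=C\c1ccccc1OC` gives 4900 nM in a functional assay on A549 cells (Homo sapiens) for cytotoxicity, read by CCK-8 assay, with a stated time of 72 h; on this read-out higher numbers stand for weaker inhibition and lower numbers for stronger inhibition
compound 2 `COc1ccccc1/C=c1\c(=O)[nH]/c(=C/c2ccccc2Cl)c(=O)n1C` gives 300 nM in this assay
compound 3 `C=CCn1c(=O)/c(=C\c2ccccc2OC)[nH]c(=O)/c1=C\c1ccccc1OC` gives 22400 nM in this assay

Compound 3 stands highest of the three numbers in this assay; compound 1 is nearest, compound 2 furthest below it. For the measured compounds named here, the one step measured is a 4.6-fold higher number from compound 1 to compound 3 (0.66 log units; beyond the scatter), which shows that the 2-methoxyphenyl group on the double-bonded chain carbon carries a higher number than the 5-fluoro-2-methylphenyl group.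

Compound 4 `C=CCn1c(=O)/c(=C\c2ccccc2Cl)[nH]c(=O)/c1=C\c1ccccc1OC` differs from compound 3 by chloro in place of methoxy on an aromatic carbon; methoxy leaves and chloro enters on an aromatic carbon of the same ring, so the ring becomes 2-chlorophenyl. Going by the values given here, no step for this exact exchange is measured. Compound 2 also carries 2-chlorophenyl beside 2-methoxyphenyl and gives 300 nM, but it differs from compound 4 on the ring nitrogen too, so only its value can be cited. Taken together with the step from compound 1 to compound 3, removing the second methoxyphenyl is expected to lower the number in this assay by a modest step, a 6.4-fold lower number from compound 3 to compound 4 (0.81 log units; beyond the scatter). Compound 4 is therefore estimated at 3500 nM in this assay, with a range from 900 nM to 14000 nM.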

Compound 4, half-maximal inhibitory concentration: 5300 nM
Compound 4: middle estimate off by 1.5-fold (0.18 log units), on the low side; low and high end bracket the measured number.
By their numbers in this assay, from the lowest: compound 2; then compounds 1 and 4 (each within the scatter of the next); then compound 3.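

Replacing 2-methoxyphenyl with 2-chlorophenyl at this position in this assay gives a 4.2-fold lower number from compound 3 to compound 4 (0.63 log units; beyond the scatter), so 2-methoxyphenyl now carries the higher number against two different rings rather than one. Those two other rings are not separated from each other, the step being a 1.1-fold higher number from compound 1 to compound 4 (0.03 log units; within the scatter), and that step lies within the scatter, so neither 2-chlorophenyl nor 5-fluoro-2-methylphenyl can be ranked above the other on this core. For the compounds shown here, the only large step so far lies at the ring nitrogen and not on the aromatic ring: vinyl in place of hydrogen on the saturated chain carbon bound to the aromatic nitrogen gives an 18-fold higher number from compound 2 to compound 4 (1.25 log units; beyond the scatter), so the substituent on that nitrogen matters at least as much as the exchange on the ring.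

On these data alone, it remains open whether an amine or a carboxylic acid at the end of a longer chain on that nitrogen, or a nitrile in place of chloro on the aromatic ring, would move the number further. Nothing at hand bears on why these numbers shift as they do.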